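The source may hold more compounds than are shown below. What is called first, only, known or untested is meant among the compounds shown, and "the series" means these compounds.

Measured so far:
Compound 1, `O=C1/C(=C\c2ccccc2)N=C(c2ccccc2)N1c1ccc2oc(-c3ccccc3)cc(=O)c2c1`: 20.9 ug/mL
Compound 2, `O=C1/C(=C\c2ccc(Cl)c(Cl)c2)N=C(c2ccccc2)N1c1ccc2oc(-c3ccccc3)cc(=O)c2c1`: 16 ug/mL

Both compounds were tested in a functional assay on HeLa cells (Homo sapiens) for inhibition, read by sulforhodamine B assay; a higher number here means a weaker inhibitor, a lower number a stronger inhibitor. Compound 2 stands at one end of these two numbers, compound 1 at the other, and the gap between them, a 1.3-fold lower number from compound 1 to compound 2 (0.12 log units; within the scatter), is within the scatter, so the two compounds cannot be told apart on this evidence.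

Compound 3, `COc1ccc(/C=C2/N=C(c3ccccc3)N(c3ccc4oc(-c5ccccc5)cc(=O)c4c3)C2=O)cc1OC`, shares the core of compound 2 and differs from it in one place: 3,4-dimethoxyphenyl in place of 3,4-dichlorophenyl on a double-bonded chain carbon bound to a double-bonded ring carbon. For the measured compounds named here, the only step that bears on this position is the one from compound 1 to compound 2, a 1.3-fold lower number from compound 1 to compound 2 (0.12 log units; within the scatter), which stayed within the scatter when the group at this position was exchanged. Going by the values given here, no measured pair shows a methoxy-bearing ring at this position, so the expectation rests on that single step alone. The step expected from compound 2 to compound 3 in this assay is therefore a 1.3-fold higher number from compound 2 to compound 3 (0.10 log units; within the scatter), that is, no change beyond the scatter. Compound 3 is estimated at 20 ug/mL in this assay, with a range from 8 ug/mL to 50 ug/mL.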

Compound 3, half-maximal inhibitory concentration: 11.1 ug/mL
Compound 3: middle estimate off by 1.8-fold (0.26 log units), on the high side; measured number inside the range.
By their numbers in this assay, from the lowest: compounds 3, 2 and 1 (each within the scatter of the next).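

In this assay, putting 3,4-dimethoxyphenyl in place of 3,4-dichlorophenyl gives a 1.4-fold lower number from compound 2 to compound 3 (0.16 log units; within the scatter) and putting it in place of the unsubstituted phenyl gives a 1.9-fold lower number from compound 1 to compound 3 (0.27 log units; within the scatter), so neither exchange can be told from repeat-measurement noise. The earlier pair showed only that the unsubstituted phenyl and the 3,4-dichlorophenyl group could not be separated here; this result adds a third group, one carrying hydrogen-bond acceptors that the other two lack, and it too cannot be separated from either of them, so among these three compounds no group at this position stands apart. Nothing available here offers an explanation for how closely these numbers sit, and no measurement beyond this cell assay bears on them.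

Still open, from the compounds shown here alone, is whether an amine or a carboxylic acid on this ring, or a longer chain such as ethoxy in place of methoxy, would produce a step beyond the scatter. Also open, going by these compounds, is whether a ring with a single chlorine or a single methoxy group would read like these, and the three compounds say nothing about any other part of the shared core.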